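Two Methyls for Two Hydroxyls on the Side-Chain Ring

The source may hold more compounds than are shown below. What is called first, only, known or untested is meant among the compounds shown, and "the series" means these compounds.

Measured so far:
compound 1, `O=C(/C(=C\c1ccc(Br)cc1)SCc1ccc(Cl)cc1)c1ccc(Cl)cc1`, in a functional assay on DU-145 cells (Homo sapiens) for inhibition, read by trypan blue exclusion, with a stated time of 96 h (on this read-out lower numbers stand for stronger inhibition of growth and higher numbers for weaker inhibition of growth), gives 1000 nM
compound 2, `CSc1ccc(/C=C(/SCc2ccc(Cl)cc2)C(=O)c2ccc(Cl)cc2)cc1`, gives 25000 nM
compound 3, `O=C(/C(=C\c1ccc(O)cc1O)SCc1ccc(Cl)cc1)c1ccc(Cl)cc1`, gives 50000 nM

Compound 3 carries the largest number of the three. The step of a 2.0-fold higher number from compound 2 to compound 3 (0.30 log units; within the scatter) keeps compound 2 and compound 3 within the usual scatter of each other, but the step of a 50-fold higher number from compound 1 to compound 3 (1.70 log units; beyond the scatter) sets compound 3 clearly apart from compound 1.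

Compound 4 is `Cc1cc(C)cc(/C=C(/SCc2ccc(Cl)cc2)C(=O)c2ccc(Cl)cc2)c1`. It differs from compound 3 in one place: 3,5-dimethylphenyl in place of 2,4-dihydroxyphenyl on a double-bonded chain carbon bound to a double-bonded chain carbon.

Going by the values given here, the steps that bear on this change are those that alter the same ring on the double-bonded chain carbon. Both a 50-fold higher number from compound 1 to compound 3 (1.70 log units; beyond the scatter) and a 2.0-fold higher number from compound 2 to compound 3 (0.30 log units; within the scatter) end at compound 3, and the only ring without hydrogen-bond donors or acceptors in that position, in compound 1, goes with the lowest number. Among the compounds with values here, compound 4 likewise carries no donors or acceptors there, so a lower number than compound 3 is expected, though no measured pair tests the 3,5-dimethylphenyl group itself, and the size is uncertain.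

Compound 4 is therefore estimated at 5000 nM, with a plausible range from 1000 nM to 30000 nM, which would mean an expected step of a 10-fold lower number from compound 3 to compound 4 (1.00 log units; beyond the scatter).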

Compound 4, concentration for 50% growth inhibition: 10000 nM
Compound 4: the middle estimate sits 2.0-fold (0.30 log units) below what was measured; low and high end bracket the measured number.
By their numbers in this assay, from the lowest: compound 1; then compound 4; then compounds 2 and 3 (each within the scatter of the next).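

In this assay, putting 3,5-dimethylphenyl in place of 2,4-dihydroxyphenyl on the double-bonded chain carbon gives a 5.0-fold lower number from compound 3 to compound 4 (0.70 log units; beyond the scatter), so this position responds to a swap between two rings of equal heavy-atom count, one with hydrogen-bond donors and one with none. The new ring also stands clear of the 4-(methylsulfanyl)phenyl ring, with a 2.5-fold lower number from compound 2 to compound 4 (0.40 log units; beyond the scatter), which separates it from two rings whose values lay within the scatter of each other, yet it does not match the 4-bromophenyl ring, as a 10-fold higher number from compound 1 to compound 4 (1.00 log units; beyond the scatter) shows. Removing the hydroxyl groups therefore accounts for only part of the gap to the best compound here, and no measurement available explains why these rings differ.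

The swap changes both the kind of group and where the groups sit on the ring, so the effect of each cannot be told apart from these compounds. A 2,4-dimethylphenyl or 3,5-dihydroxyphenyl ring would separate the two, and a 3,5-dibromophenyl ring would show whether the bromo group keeps its advantage at those ring positions.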